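Cyclopentyl in place of furan-2-yl on the shared core

The source may report more compounds than this note shows. Statements on the series, on what has been measured and on what is new or still open speak of the compounds shown alone.

Measured so far in a functional assay on KBVIN cells (Homo sapiens) for cytotoxicity, read by MTT assay, with a stated time of 72 h; on this read-out higher numbers stand for an effect only at larger amounts of compound and lower numbers for an effect already at smaller amounts
- Compound 1 `COc1ccc(Nc2cc(/C=C/c3ccccc3)oc(=O)c2)cc1` gives 0.1 uM
- Compound 2 `COc1ccc(Nc2cc(-c3ccco3)oc(=O)c2)cc1` gives 1.46 uM

Compound 2 holds the higher of the two numbers, 1.46 uM, in this assay. Compound 3 `COc1ccc(Nc2cc(C3CCCC3)oc(=O)c2)cc1` carries cyclopentyl in place of furan-2-yl on an aromatic carbon next to the ring oxygen (cyclopentyl in place of furan-2-yl on an aromatic carbon). For the measured compounds named here, the one measured step at this place is large, a 15-fold higher number from compound 1 to compound 2 (1.16 log units; beyond the scatter), but it involves 2-phenylethenyl and says nothing direct about cyclopentyl. The expected change is therefore modest, a 1.7-fold higher number from compound 2 to compound 3 (0.23 log units; within the scatter), and not beyond the scatter. For compound 3 the estimated value is 2.5 uM, with an expected range from 0.6 uM to 10 uM.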

Compound 3, concentration for half-maximal effect: 4.98 uM
Estimate against measurement, compound 3: 2.0-fold (0.30 log units) below, and the stated range covers the measured number.
By their numbers in this assay, from the lowest: compound 1; then compound 2; then compound 3.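

In this assay, cyclopentyl in place of furan-2-yl gives a 3.4-fold higher number from compound 2 to compound 3 (0.53 log units; beyond the scatter) even though both groups have the same number of heavy atoms, so this position separates an aromatic ring from a non-aromatic ring of carbon only. Against 2-phenylethenyl, the same group gives a 50-fold higher number from compound 1 to compound 3 (1.70 log units; beyond the scatter) and this is the largest step among the compounds shown. Nothing available bears on why the numbers fall in this order.

The compounds shown leave open where cyclohexyl, a longer alkyl chain or an amine on this aromatic carbon would fall.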